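Chloro addition on the arylidene ring: first pass

The source may hold more compounds than are shown below. What is called first, only, known or untested is meant among the compounds shown, and "the series" means these compounds.

Compound 1 `O=C1NC(=S)/C(=C/c2cccc(Cl)c2)S1` gives 21.6% in a functional assay on NCI-H292 cells (Homo sapiens) for cytotoxicity, read by MTT assay, with a stated time of 72 h, tested at 5 ug/mL; a higher number here means more inhibition of growth at the concentration tested, a lower number less inhibition of growth. Compound 2 `O=C1NC(=S)/C(=C/c2ccccc2Cl)S1` gives 34.2% in this assay, and compound 3 `O=C1NC(=S)/C(=C/c2ccc(Cl)c(Cl)c2)S1` gives 35.8%. Compound 2 and compound 3 lie within the scatter of each other, while compound 2 stands beyond the scatter of compound 1. Compound 1 and compound 2 have the same atoms joined differently; the difference between the two cores is not broken down here.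

From compound 1 to compound 3 the change is chloro in place of hydrogen on an aromatic carbon, and the step in this assay is a number 14.2 percentage points higher from compound 1 to compound 3 (beyond the scatter). Compound 4 `O=C1NC(=S)/C(=C/c2ccc(Cl)cc2Cl)S1` is not yet measured. It differs from compound 2 by chloro in place of hydrogen on an aromatic carbon. For the measured compounds named here, this is the same kind of change as the one from compound 1 to compound 3, not the same: in compound 3 the entering chloro is ortho to a chloro group, in compound 4 it is meta to a chloro group, and in both it is para to a group of 8 heavy atoms. Because a number 14.2 percentage points higher from compound 1 to compound 3 (beyond the scatter) was seen, a step of similar size is expected here, a number 11.8 percentage points higher from compound 2 to compound 4 (beyond the scatter), though it rests on a single example. Compound 4 is estimated at 46%, expected between 30% and 62%.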

Compound 4, percent growth inhibition at one concentration: 29.3%
The estimate for compound 4 lay 16.7 percentage points above the measured number; the measured number lies below the stated range.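

In this assay, adding the chloro gives a number 4.9 percentage points lower from compound 2 to compound 4 (within the scatter), so on this core the change has no effect that can be told from scatter. Set beside the earlier step, the same change does not carry over as a fixed gain between the two cores: the same change on two cores in this assay, a number 14.2 percentage points higher (beyond the scatter) from compound 1 to compound 3 and a number 4.9 percentage points lower (within the scatter) from compound 2 to compound 4, 19.1 percentage points apart, beyond the scatter of two such steps This shows that the step seen on the core of compound 1 cannot be used as a general increment for this series; it does not show why the steps differ, since the entering chloro also sits differently in the two pairs, here meta to a chloro group, and a single pair per core cannot separate the core from that placement.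

All substituents on the aromatic ring shown so far are chloro groups, so it remains open whether a methoxy group, an amine or a carboxylic acid at the same carbon would follow either step. Further matched pairs would be needed to show which of the two steps is the more typical.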